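A few compounds are considered here, and "the series" means these few. Any claim that something is new, unique, unknown or untested is made for them only; others in the source may bear on it.

Compound 1, `NC(=O)CC[C@H](NS(=O)(=O)c1ccc([N+](=O)[O-])cc1)C(=O)O`: in a functional assay on MDA-MB-231 cells (Homo sapiens) for cytotoxicity, read by MTT assay, with a stated time of 48 h (a lower number here means a stronger inhibitor, a higher number a weaker inhibitor), compound 1 gives > 500000 nM.
Compound 2, `CNC(=O)CC[C@H](NS(=O)(=O)c1ccc([N+](=O)[O-])cc1)C(=O)O`: in this assay compound 2 gives > 500000 nM.

Both of these values are limits of the assay rather than numbers. For compound 1 the value > 500000 nM is a limit, saying only that no half-maximal inhibition was reached within the tested range. Compound 1 therefore stands at the limit of > 500000 nM in this assay, at which 2 of the 2 values shown sit, and nothing measured here places it more precisely. The step that the two limits leave unreadable from compound 1 to compound 2 cannot be read, since both of its ends are limits.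

Compound 3, `O=C(CC[C@H](NS(=O)(=O)c1ccc([N+](=O)[O-])cc1)C(=O)O)NCc1ccccc1`, has not yet been measured. It differs from compound 1 in one place: benzyl in place of hydrogen on an amide-type nitrogen. Going by the values given here, the only measured step, from compound 1 to compound 2, also changes what sits on this amide-type nitrogen, yet its size is not readable, so it gives no guide to how large a change to expect in this assay, and no direction beyond the scatter can be set from it. For compound 3 a value of 500000 nM is expected, within 100000 nM to 2000000 nM, with a fair chance that only a limit is again reported. The expected step is a number no higher from compound 1 to compound 3 (the limit leaves the size open), meaning no change that can be read.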

Compound 3, half-maximal inhibitory concentration: 175000 nM
Compound 3: middle estimate off by 2.9-fold (0.46 log units), on the high side, within the range that was stated.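

In this assay, going by these compounds alone, compound 3 is the first compound here to give a number rather than a limit, so a change on this amide-type nitrogen can now be sized: benzyl in place of hydrogen gives an at least 2.8-fold lower number from compound 1 to compound 3 (0.45 log units; beyond the scatter) and points to a stronger inhibitor. Compared with the methyl of compound 2, phenyl in place of hydrogen on the saturated chain carbon bound to this nitrogen gives an at least 2.8-fold lower number from compound 2 to compound 3 (0.45 log units; beyond the scatter), so the same direction appears from both starting points. Both sizes are minimums, and the step between the two earlier compounds cannot be read, since compound 1 and compound 2 each give only a limit: the limit of > 500000 nM in this assay, at which 2 of the 3 values shown sit.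

On these data alone, it remains open whether the aromatic ring of benzyl is what counts, which a cyclohexylmethyl group or a phenethyl group on the same nitrogen could help to separate. All three compounds also keep the same nitro group and carboxylic acid, so nothing here shows whether the benzyl step would hold with an amine in place of the nitro group or a methyl ester in place of the acid.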